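Compound 3 and One Added Methoxy

The compounds below may be only part of what the source reports. "The series", "measured", "known", "first", "only" and "open" are said of these compounds alone.

Three compounds sharing one core come first: compound 1 (`CC(=O)c1ccc2[nH]c(-c3ccccc3)nc2c1`), compound 2 (`CC(=O)c1ccc2[nH]c(-c3ccc(Cl)cc3)nc2c1`) and compound 3 (`COc1ccc(-c2nc3cc(C(C)=O)ccc3[nH]2)c(OC)c1`). In an ADME assay on MT4 cells (Homo sapiens) for cytotoxicity, read by MTT assay, with a stated time of 96 h (on this read-out higher numbers stand for lower toxicity in this test and lower numbers for higher toxicity in this test), the entry for compound 1 reads "not determined" (no result reported) and the entry for compound 2 reads "not determined" (no result reported) with no number behind it. Among the measured compounds shown here, compound 3 gives 50000 nM as the only number in the set, so it has no rank against any other compound. Compound 4 (`COc1ccc(-c2nc3cc(C(C)=O)ccc3[nH]2)c(OC)c1OC`) carries methoxy in place of hydrogen on an aromatic carbon of compound 3 (methoxy in place of hydrogen on an aromatic carbon) and differs in nothing else. For the measured compounds named here, with compound 3 at 50000 nM as the sole anchor and no measured pair showing this change in this assay no step beyond the scatter is expected in either direction. The expected move is no change at the digits printed from compound 3 to compound 4 (within the scatter) and stays within the scatter. Compound 4 is expected near 50000 nM (estimated range 25000 nM to 100000 nM).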

Compound 4, half-maximal cytotoxic concentration: > 100000 nM
Compound 4: only a limit was reported; the forecaster's own chance of this, stated with the estimate: 30%; at least 2.0-fold (0.30 log units) between middle value and limit.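

In this assay, among the compounds shown here, the methoxy ortho to two methoxy groups gives an at least 2.0-fold higher number from compound 3 to compound 4 (0.30 log units; that floor lies within the scatter), the first measured step at this position. On these data alone, compound 4 gives > 100000 nM, which is a limit and not a number, so the step has only a floor and its full size stays unknown: the limit of > 100000 nM in this assay, at which 1 of the 4 values shown sits. The change therefore brings no lower number in this read-out, which would have stood for higher toxicity in this test.

The compounds shown leave open how a hydroxyl or an amine in this place would read. They also leave open whether methoxy would give the same step without two methoxy groups ortho to it.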